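Anilino-substituted tricyclic quinone series: step toward compound 4

This account rests on a few compounds, and the source may have more. Where it says the series, first, only, none or still open, it means among the compounds named here.

Measured so far:
compound 1 `O=C1C(Nc2ccccc2F)=CC(=O)c2c1nc1n2[C@H]2OC[C@@H](O)[C@H]2OC1`, 2000 nM
compound 2 `O=C1C=C(Nc2ccccc2F)C(=O)c2c1nc1n2[C@H]2OC[C@@H](O)[C@H]2OC1`, 2080 nM
compound 3 `Cc1ccc(NC2=CC(=O)c3nc4n(c3C2=O)[C@H]2OC[C@@H](O)[C@H]2OC4)cc1C`, 860 nM

In a functional assay on MGC-803 cells (Homo sapiens) for inhibition, read by sulforhodamine B assay (on this read-out lower numbers stand for stronger inhibition and higher numbers for weaker inhibition), compound 1 gives 2000 nM, the second highest of the three numbers. Compound 2 gives 2080 nM, which lies within the scatter of compound 1, so no order between the two can be read. Among the compounds with values here, compound 3, with 860 nM, stands beyond the scatter on the lower side; the only single-place step in the set, a 2.4-fold lower number from compound 2 to compound 3 (0.38 log units; beyond the scatter), is a modest one and concerns the aryl group on the amine nitrogen.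

Compound 4 `O=C1C(Nc2cccc(Cl)c2)=CC(=O)c2c1nc1n2[C@H]2OC[C@@H](O)[C@H]2OC1` differs from compound 1 in one place: 3-chlorophenyl in place of 2-fluorophenyl on an amine nitrogen. This is again an aryl swap on the amine nitrogen, comparable in kind to the step seen between compounds 2 and 3, though that step exchanged 2-fluorophenyl for 3,4-dimethylphenyl and not for 3-chlorophenyl, and started from the other arrangement of the shared core. Within the data shown here, no measured pair shows the chlorine-bearing aryl itself. The expectation is therefore a step of at most modest size in this assay, if anything toward a lower number, with a real chance that it stays within the scatter. Compound 4 is estimated at 1300 nM, range 500 nM to 3500 nM, corresponding to an expected step of a 1.5-fold lower number from compound 1 to compound 4 (0.19 log units; within the scatter).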

Compound 4, half-maximal inhibitory concentration: 1530 nM
Compound 4: the middle estimate sits 1.2-fold (0.07 log units) below what was measured, and the stated range covers the measured number.
By their numbers in this assay, from the lowest: compounds 3, 4, 1 and 2 (each within the scatter of the next, the first and the last beyond it).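

In this assay, the change on the amine nitrogen in the arrangement of the shared core found in compound 1 gives a 1.3-fold lower number from compound 1 to compound 4 (0.12 log units; within the scatter), so exchanging 2-fluorophenyl for 3-chlorophenyl produces no readable shift. Within the data shown here, the only earlier single-place step, a 2.4-fold lower number from compound 2 to compound 3 (0.38 log units; beyond the scatter), came from the other arrangement of the core and brought in a different aryl group, so this pair adds the first reading from the arrangement of compound 1 and shows that not every aryl swap at this nitrogen gives a step beyond the scatter. No measurement shown here bears on the reason for this result.

The compounds shown leave open whether 3,4-dimethylphenyl would give a comparable step in the arrangement of compound 1, and whether 3-chlorophenyl would behave the same way in the arrangement of compound 2. Also open, from the compounds shown here alone, is how the read-out responds when the aryl group on the amine nitrogen gives way to a cyclohexyl group, or when the phenyl ring carries a carboxylic acid.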